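Taking the 4-methylpiperazin-1-yl group off compound 3

The compounds below may be only part of what the source reports. "The series", "measured", "known", "first", "only" and "open" are said of these compounds alone.

In a functional assay on HL60/MX2 cells (Homo sapiens) for antiproliferative activity, read by MTT assay, with a stated time of 48 h (on this read-out lower numbers stand for stronger inhibition and higher numbers for weaker inhibition), compound 1 (`Cn1c(N)c(-c2nc3ccccc3[nH]2)c2nc(C#N)c(C#N)nc21`) reaches only a limit of the assay, > 50000 nM, and not a number. Compound 2 (`CN(C)CCn1c(N)c(-c2nc3ccccc3[nH]2)c2nc(C#N)c(C#N)nc21`) gives 3780 nM and compound 3 (`CN1CCN(CCCn2c(N)c(-c3nc4ccccc4[nH]3)c3nc(C#N)c(C#N)nc32)CC1`) gives 3320 nM, so these two stand level, with a 1.1-fold lower number from compound 2 to compound 3 (0.06 log units; within the scatter). Together they hold the low end of the numbers so far.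

Compound 4 (`CCCCn1c(N)c(-c2nc3ccccc3[nH]2)c2nc(C#N)c(C#N)nc21`) differs from compound 3 in one place: methyl in place of 4-methylpiperazin-1-yl on a saturated chain carbon, three bonds along the chain from an aromatic nitrogen. This puts methyl in place of 4-methylpiperazin-1-yl, three bonds along the chain from an aromatic nitrogen, and leaves a butyl group.

For the measured compounds named here, two measured steps bear most on this change, both of them large: an at least 13-fold lower number from compound 1 to compound 2 (1.12 log units; beyond the scatter) and an at least 15-fold lower number from compound 1 to compound 3 (1.17 log units; beyond the scatter). Each leads to a chain ending in dimethylamino or 4-methylpiperazin-1-yl. Going by the values given here, compound 4 keeps the chain length of compound 3 but loses that end, and no measured compound separates the effect of chain length from that of the end group. A move part of the way back towards compound 1 therefore seems likely.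

The expected step is a 6.0-fold higher number from compound 3 to compound 4 (0.78 log units; beyond the scatter), towards weaker inhibition. Compound 4 is estimated at 20000 nM, with an expected range from 6000 nM to 50000 nM.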

Compound 4, half-maximal inhibitory concentration: > 50000 nM
Compound 4 gave a limit, no number; the forecaster's own chance of this, stated with the estimate: 35%; middle value at least 2.5-fold (0.39 log units) away from the limit.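

In this assay compound 4 gives > 50000 nM, which is a limit of the assay and not a number. Putting methyl in place of 4-methylpiperazin-1-yl gives an at least 15-fold higher number from compound 3 to compound 4 (1.17 log units; beyond the scatter), and ethyl in place of dimethylamino gives an at least 13-fold higher number from compound 2 to compound 4 (1.12 log units; beyond the scatter), so the length of the chain alone does not bring the activity seen with compound 2 and compound 3: a plain butyl group on the same aromatic nitrogen loses it, and among these compounds a number below the limit appears only where the chain ends in one of the two amines. How compound 1 and compound 4 compare cannot be read, because both sit at the same limit: the limit of > 50000 nM in this assay, at which 2 of the 4 values shown sit.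

Going by these compounds, it remains open whether the end of the chain has to be an amine at all, or whether a hydroxyl group or a carboxylic acid at the same place would serve as well. On these data alone, it is also open how a primary amine, or a morpholine ring, would behave at the end of the chain, and whether a longer chain carrying 4-methylpiperazin-1-yl would change the number.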